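The compounds below may be only part of what the source reports. "The series", "measured", "known", "first", "only" and "open" are said of these compounds alone.

Measured so far in a functional assay on HCT-116 cells (Homo sapiens) for inhibition, read by sulforhodamine B assay, with a stated time of 3 days; a higher number here means a weaker inhibitor of growth, a lower number a stronger inhibitor of growth
- compound 1 `O=C(/C=C/c1ccc(Cl)cc1)c1ccccc1` gives 16500 nM
- compound 2 `COc1cccc(/C=C/C(=O)c2ccc(OCc3ccccc3)cc2)c1` gives 35400 nM
- compound 3 `O=C(/C=C/c1ccc(F)cc1)c1ccccc1` gives 4360 nM

Compound 2 stands highest of the three at 35400 nM and so is the weakest growth inhibitor among them. Compound 4 `O=C(/C=C/c1ccc(Cl)cc1)c1ccc(OCc2ccccc2)cc1` differs from it in one place, as 4-chlorophenyl in place of 3-methoxyphenyl on a double-bonded chain carbon bound to a double-bonded chain carbon shows, with 4-chlorophenyl in place of 3-methoxyphenyl on a double-bonded chain carbon bound to a double-bonded chain carbon. Among the compounds with values here, the only measured step is a 3.8-fold lower number from compound 1 to compound 3 (0.58 log units; beyond the scatter) for fluoro in place of chloro on an aromatic carbon, which is modest and involves no methoxy group. Compound 1 carries the same 4-chlorophenyl and gives 16500 nM as a lower number than compound 2 shows. A modest fall is therefore expected, with a 1.8-fold lower number from compound 2 to compound 4 (0.25 log units; within the scatter) as the estimated step in this assay and with little certainty. For compound 4 the estimated value is 20000 nM with an expected range of 7000 nM to 50000 nM around it.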

Compound 4, concentration for 50% growth inhibition: > 50000 nM
Compound 4 gave a limit, no number; the forecaster's own chance of this, stated with the estimate: 10%; middle value at least 2.5-fold (0.39 log units) away from the limit.
By their numbers in this assay, from the lowest: compound 3; then compound 1; then compound 2. At a limit, above all of these: compound 4.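

Compound 4 gives > 50000 nM, which is a limit of the assay and not a number. Adding the benzyloxy group to the core of compound 1 clearly weakens growth inhibition, with benzyloxy in place of hydrogen on an aromatic carbon giving an at least 3.0-fold higher number from compound 1 to compound 4 (0.48 log units; beyond the scatter). From the compounds shown here alone, putting 4-chlorophenyl in place of 3-methoxyphenyl gives an at least 1.4-fold higher number from compound 2 to compound 4 (0.14 log units; that floor lies within the scatter), so with benzyloxy present this change shows no gain, and its true size stays unknown.

Still open, going by these compounds, is whether a smaller group at the benzyloxy position, such as an amine or a carboxylic acid, would preserve growth inhibition.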